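The compounds below may be only part of what the source reports. "The series", "measured", "known", "first", "only" and "open" are said of these compounds alone.

Three compounds have been measured in an assay on CHO cells for antagonist activity at transient receptor potential cation channel subfamily V member 1 (Homo sapiens), read by FLIPR; a higher number here means a weaker inhibitor, a lower number a stronger inhibitor:
Compound 1, `CC(C(=O)NCc1ccc(C(F)(F)F)nc1-c1ccccc1F)c1ccc(NS(C)(=O)=O)c(F)c1`, gives 63.3 nM.
Compound 2, `CC(C(=O)NCc1ccc(C(F)(F)F)nc1-c1ccc(N(C)C)cc1)c1ccc(NS(C)(=O)=O)c(F)c1`, gives 3.2 nM.
Compound 3, `CC(C(=O)NCc1ccc(C(F)(F)F)nc1-c1ccc(C(C)(C)C)cc1)c1ccc(NS(C)(=O)=O)c(F)c1`, gives 0.5 nM.

Compound 3 has the lowest number of the three in this assay: compound 2 is nearest, with a 6.4-fold lower number from compound 2 to compound 3 (0.81 log units; beyond the scatter), and compound 1 is furthest, with a 130-fold lower number from compound 1 to compound 3 (2.10 log units; beyond the scatter). All three share the same core and differ only in the phenyl ring that sits on an aromatic carbon of a six-membered aromatic ring with 1 nitrogen, next to the ring nitrogen.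

Compound 4, `Cc1cc(-c2nc(C(F)(F)F)ccc2CNC(=O)C(C)c2ccc(NS(C)(=O)=O)c(F)c2)ccc1F`, has not yet been measured. Its change from compound 3 is 4-fluoro-3-methylphenyl in place of 4-(tert-butyl)phenyl on an aromatic carbon. The entering ring carries a fluorine and a methyl where compound 3 carried a tert-butyl.

Both earlier steps changed this same ring. a 130-fold lower number from compound 1 to compound 3 (2.10 log units; beyond the scatter) shows that going from 2-fluorophenyl to 4-(tert-butyl)phenyl lowers the number greatly, and a 6.4-fold lower number from compound 2 to compound 3 (0.81 log units; beyond the scatter) shows that between 4-(dimethylamino)phenyl and 4-(tert-butyl)phenyl the tert-butyl still gives a clearly lower number. Compound 4 keeps a substituted phenyl but loses the tert-butyl, so a higher number than compound 3 is expected, though not one as high as compound 1 shows. The expected step is a 10-fold higher number from compound 3 to compound 4 (1.00 log units; beyond the scatter). Compound 4 is estimated at 5 nM, with a range from 1.5 nM to 20 nM.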

Compound 4, inhibition constant: 0.4 nM
For compound 4 the middle estimate is 13-fold (1.10 log units) above the measured one; measured number outside the range, below it.
By their numbers in this assay, from the lowest: compounds 4 and 3 (each within the scatter of the next); then compound 2; then compound 1.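

In this assay, the smaller 4-fluoro-3-methylphenyl ring on the aromatic carbon next to the ring nitrogen does as well as 4-(tert-butyl)phenyl (a 1.3-fold lower number from compound 3 to compound 4 (0.10 log units; within the scatter)), so a tert-butyl group is not needed here for a number this low. The gains over the other two rings also show that a ring fluorine does not by itself keep the number high: compound 4 carries one, yet it stands well below the 4-(dimethylamino)phenyl compound (an 8.0-fold lower number from compound 2 to compound 4 (0.90 log units; beyond the scatter)) and far below the 2-fluorophenyl compound (a 160-fold lower number from compound 1 to compound 4 (2.20 log units; beyond the scatter)). No measurement is available to explain why two such different rings give numbers this close.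

Going by these compounds, it remains open whether the fluorine, the methyl or the two together account for the low number of compound 4, and a phenyl ring carrying only one of them would help to separate these cases. The compounds shown also leave open how a phenyl ring bearing a carboxylic acid, a primary amine or a longer alkyl chain would behave at this position.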